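This account rests on a few compounds, and the source may have more. Where it says the series, first, only, none or still open, it means among the compounds named here.

Measured compounds in an assay on isolated protein for inhibition of thyroid hormone receptor beta (Homo sapiens), read by fluorescence, with a stated time of 30 min; on this read-out lower numbers stand for stronger inhibition and higher numbers for weaker inhibition:
compound 1 `COc1cc(C(=O)N2CCC(C)(C)C2)cc2nc(NCc3cccc(Cl)c3)oc12` — 40 nM
compound 2 `COc1cc(C(=O)N2CC[C@@H](O)[C@H](C)C2)cc2nc(NCc3cccc(Cl)c3)oc12` — 10 nM
compound 3 `CCC1CC(O)C(C)CN1C(=O)c1cc(OC)c2oc(NCc3cccc(Cl)c3)nc2c1` — 13 nM

Compound 3 stands second highest of the three numbers in this assay. Against compound 1 the step is a 3.1-fold lower number from compound 1 to compound 3 (0.49 log units; beyond the scatter); against compound 2 the step is a 1.3-fold higher number from compound 2 to compound 3 (0.11 log units; within the scatter), so compounds 2 and 3 cannot be told apart on these data.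

Compound 4 `COc1cc(C(=O)N2CC(C)C(O)CC2CCO)cc2nc(NCc3cccc(Cl)c3)oc12` differs from compound 3 by hydroxy in place of hydrogen on a saturated chain carbon, two bonds along the chain from a saturated ring carbon. Within the data shown here, no measured step changes this chain carbon. The step nearest in kind is a 1.3-fold higher number from compound 2 to compound 3 (0.11 log units; within the scatter), in which the ethyl chain itself entered the ring without a step beyond the scatter. The steps of a 4.0-fold lower number from compound 1 to compound 2 (0.60 log units; beyond the scatter) and a 3.1-fold lower number from compound 1 to compound 3 (0.49 log units; beyond the scatter) each brought a hydroxy onto a ring carbon together with a change of the ring itself, so they do not isolate the effect of a hydroxy alone and give only a loose pointer toward a lower number.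

The expected step is therefore a 1.1-fold lower number from compound 3 to compound 4 (0.03 log units; within the scatter), none beyond the scatter. For compound 4 the estimate in this assay is 12 nM, within 5 nM to 35 nM.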

Compound 4, half-maximal inhibitory concentration: 0.27 nM
For compound 4 the middle estimate is 44-fold (1.65 log units) above the measured one, and the stated range ends above it.
By their numbers in this assay, from the lowest: compound 4; then compounds 2 and 3 (each within the scatter of the next); then compound 1.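

In this assay, among these compounds, this saturated chain carbon proves far more sensitive than the earlier compounds showed: ethyl to 2-hydroxyethyl alone gives a 48-fold lower number from compound 3 to compound 4 (1.68 log units; beyond the scatter) in a single-place change, whereas the ethyl chain itself had brought no step beyond the scatter. The 4-hydroxy-2-(2-hydroxyethyl)-5-methylpiperidin-1-yl amide also stands clear of the other two, with a 37-fold lower number from compound 2 to compound 4 (1.57 log units; beyond the scatter) and a 150-fold lower number from compound 1 to compound 4 (2.17 log units; beyond the scatter) as its further steps, so compound 4 has the lowest number of the series, beyond the scatter of all three others. Nothing at hand accounts for the size of this step.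

Still open, on these data alone, is whether the gain belongs to the hydroxy as such, or would also come with a methyl ether, an amine or a carboxylic acid on this chain carbon. Also open, as far as these compounds go, is whether a longer chain carrying the hydroxy would keep the gain.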